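Fluoro for chloro: compound 3 to compound 4

The source may hold more compounds than are shown below. What is called first, only, known or untested is meant among the compounds shown, and "the series" means these compounds.

In an ADME assay on HEK293 cells (Homo sapiens) for cytotoxicity, read by MTT assay, with a stated time of 72 h (on this read-out lower numbers stand for stronger inhibition and higher numbers for weaker inhibition), compound 1 `COc1ccc2[nH]cc(CCCN3CCN(C(=O)CN4CCN(C(=O)c5ccccc5)CC4)CC3)c2c1` reads > 200000 nM, a limit and not a number. Compound 2 `COc1ccc(C(=O)N2CCN(CC(=O)N3CCN(CCCc4c[nH]c5ccc(OC)cc45)CC3)CC2)cc1` gives 190000 nM. Compound 3 `COc1ccc2[nH]cc(CCCN3CCN(C(=O)CN4CCN(C(=O)c5cccc(Cl)c5)CC4)CC3)c2c1` gives 143000 nM, and the gap between these two numbers is a 1.3-fold lower number from compound 2 to compound 3 (0.12 log units; within the scatter).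

Compound 4 `COc1ccc2[nH]cc(CCCN3CCN(C(=O)CN4CCN(C(=O)c5cccc(F)c5)CC4)CC3)c2c1` follows with fluoro in place of chloro on an aromatic carbon, meta to a large group. Going by the values given here, the closest precedent is the chloro-for-hydrogen step, an at least 1.3-fold lower number from compound 1 to compound 3 (0.14 log units; that floor lies within the scatter). The methoxy step, an at least 1.0-fold lower number from compound 1 to compound 2 (0.02 log units; that floor lies within the scatter), is also only a floor. Both are bounded by the limit of > 200000 nM in this assay, at which 1 of the 3 values shown sits. Neither shows a change beyond the scatter, so none is expected here in either direction. The estimated step is a 1.1-fold higher number from compound 3 to compound 4 (0.05 log units; within the scatter). Compound 4 is expected at 160000 nM, within an estimated range of 95000 nM to 220000 nM.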

Compound 4, half-maximal inhibitory concentration: > 200000 nM
Compound 4: a limit, no number; the forecaster's own chance of this, stated with the estimate: 25%; middle value at least 1.2-fold (0.09 log units) away from the limit.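

In this assay compound 4 gives a limit and not a number, so fluoro in place of chloro at this position yields only a floor: an at least 1.3-fold higher number from compound 3 to compound 4 (0.14 log units; that floor lies within the scatter). The comparison with the 4-methoxyphenyl compound also yields only a floor, an at least 1.0-fold higher number from compound 2 to compound 4 (0.02 log units; that floor lies within the scatter), and the step involving compound 1 cannot be read. Compound 1 and compound 4 both stand at a limit: the limit of > 200000 nM in this assay, at which 2 of the 4 values shown sit.

Neither floor shows a change beyond the scatter. From the compounds shown here alone, whether an amine or a carboxylic acid on this aromatic carbon would give a step beyond the scatter remains open.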